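Swapping the aryl group on a saturated ring carbon

The source may hold more compounds than are shown below. What is called first, only, known or untested is meant among the compounds shown, and "the series" means these compounds.

Of the compounds shown here, two have been measured in a functional assay on PC-3 cells (Homo sapiens) for antiproliferative activity, read by MTT assay, tested at 5 uM; a higher number here means a stronger effect of the compound at the concentration tested, a lower number a weaker effect. Compound 1, `COc1cc(C(=O)N/N=C/c2ccc(F)c(F)c2)cc(OC)c1OC`, gives 43.7%. Compound 2, `COc1ccc(C2OC(c3cc(OC)c(OC)c(OC)c3)=NN2C(C)=O)c(OC)c1`, gives 92%. Compound 2 thus stands at the top of the two numbers, and its gap to compound 1 lies beyond the scatter, so compound 2 is the stronger of the pair.

Compound 3, `COc1cc(C2=NN(C(C)=O)C(c3ccc(Cl)c([N+](=O)[O-])c3)O2)cc(OC)c1OC`, has not yet been measured. It differs from compound 2 in one place: 4-chloro-3-nitrophenyl in place of 2,4-dimethoxyphenyl on a saturated ring carbon. Going by the values given here, no measured pair shows a single change of this kind, so the size of the step cannot be read from the data; it must be guessed from the high starting point of compound 2 alone.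

A moderate drop is expected, since the aryl group that leaves and the one that enters share only their size and number of hydrogen-bond acceptors. Compound 3 is expected to give 75%, within 45% to 95%. This estimate means a step of a number 17 percentage points lower from compound 2 to compound 3 (beyond the scatter).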

Compound 3, a percentage reported as inhibition, at one concentration (the size of the read-out at that concentration, not a potency): 61.4%
Estimate against measurement, compound 3: 13.6 percentage points above; the range from low to high includes it.
By their numbers in this assay, from the lowest: compound 1; then compound 3; then compound 2.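

In this assay, going by these compounds alone, this is the first single change seen at this position, and it gives a large step: 4-chloro-3-nitrophenyl in place of 2,4-dimethoxyphenyl on the saturated ring carbon brings a number 30.6 percentage points lower from compound 2 to compound 3 (beyond the scatter) with the rest of the molecule held the same. The two aryl groups have the same count of heavy atoms and the same count of hydrogen-bond acceptors, yet the read-out moves beyond the usual scatter, so those counts alone do not fix the result at this place. Compound 3 still gives 61.4% at the tested concentration, which shows that this aryl swap lowers the effect without removing it, though nothing available gives a reason for the size of the step.

Going by these compounds, whether the drop follows the chlorine, the nitro group or the loss of the two methoxy groups stays open, since all of these change together in this one step. A plain phenyl group, or an aryl group carrying only the chlorine, only the nitro group or an amine, on that same ring carbon would pull these effects apart.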